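Changing the aryl group on a thiourea series

This account rests on a few compounds, and the source may have more. Where it says the series, first, only, none or still open, it means among the compounds named here.

Compound 1, `COc1ccccc1NC(=S)NC1CC(C)(C)Oc2ccc(Br)cc21`, gives 22000 nM in a functional assay on U-373MG ATCC cells (Homo sapiens) for inhibition, read by MTT assay, with a stated time of 72 h; a higher number here means a weaker inhibitor, a lower number a stronger inhibitor.
Compound 2, `CC1(C)CC(NC(=S)Nc2ccc([N+](=O)[O-])cc2)c2cc(Cl)ccc2O1`, gives 3000 nM.
Compound 3, `CC1(C)CC(NC(=S)Nc2ccccc2Cl)c2cc(Br)ccc2O1`, gives 34000 nM.

Compound 3 has the highest number of the three; compound 1 stands nearest to it, and compound 2 is furthest away. Going by the values given here, the single measured step that touches the present question is a 1.5-fold higher number from compound 1 to compound 3 (0.19 log units; within the scatter), which swapped a methoxy group against a chloro group on the aryl ring and moved the number only within the scatter. Compound 4, `COc1ccc(NC(=S)NC2CC(C)(C)Oc3ccc(Br)cc32)cc1`, is reached from compound 3 by one change: 4-methoxyphenyl in place of 2-chlorophenyl on an amide-type nitrogen. Compound 2 carries a much lower number than compound 3, but its aryl group and its core halogen both differ, so no single step can be read from that pair. Because the step of a 1.5-fold higher number from compound 1 to compound 3 (0.19 log units; within the scatter) was small, compound 4 is expected to land near compound 3, with at most a mild drift toward a lower number, a 1.5-fold lower number from compound 3 to compound 4 (0.19 log units; within the scatter). The estimate for compound 4 is therefore 22000 nM, with a plausible range from 9000 nM to 50000 nM.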

Compound 4, half-maximal inhibitory concentration: 40000 nM
Compound 4: the middle estimate sits 1.8-fold (0.26 log units) below what was measured; the range from low to high includes it.
By their numbers in this assay, from the lowest: compound 2; then compounds 1, 3 and 4 (each within the scatter of the next).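

In this assay, 4-methoxyphenyl in place of 2-chlorophenyl gives a 1.2-fold higher number from compound 3 to compound 4 (0.07 log units; within the scatter) and 4-methoxyphenyl in place of 2-methoxyphenyl gives a 1.8-fold higher number from compound 1 to compound 4 (0.26 log units; within the scatter) on the same amide-type nitrogen. Going by these compounds alone, the earlier compounds showed only one aryl swap at this nitrogen, while these steps show that all three aryl groups on the shared core give numbers within the scatter of each other. Nothing measured here explains this lack of separation.

On these data alone, the steps to compound 2 cannot be read, since its aryl group and its core halogen both differ from those of the other compounds, so the separate effects of its nitro group and its chlorine on the core stay open. Also open, as far as these compounds go, is whether an amine or a carboxylic acid on the aryl ring would give a number outside this narrow group.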